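Cytotoxicity of three sulfonamides and an expected fourth

A few compounds are considered here, and "the series" means these few. Any claim that something is new, unique, unknown or untested is made for them only; others in the source may bear on it.

The measured compounds in an ADME assay on HCT-116 cells (Homo sapiens) for cytotoxicity, read by CellTiter-Glo, with a stated time of 72 h; on this read-out higher numbers stand for weaker inhibition and lower numbers for stronger inhibition:
compound 1 `CC1CCN(C2CCN(S(=O)(=O)c3ccc(F)cc3F)CC2)CC1`, > 5000 nM;
compound 2 `COc1ccc(-c2cccc(S(=O)(=O)N3CCC(N4CCC(C)CC4)CC3)c2)cc1`, > 5000 nM;
compound 3 `CC1CCN(C2CCN(S(=O)(=O)c3cc(Br)cc4c3OCC4)CC2)CC1`, > 10000 nM.

Every value shown is a limit of this assay and not a number. Compound 1 sits at the limit of > 5000 nM in this assay, at which 2 of the 3 values shown sit. Compound 3 sits at the limit of > 10000 nM in this assay, at which 1 of the 3 values shown sits. None of the three compounds can be set apart from another on these values.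

Compound 4 `CC1CCN(C2CCN(S(=O)(=O)c3ccccc3Br)CC2)CC1` differs from compound 1 in one place: 2-bromophenyl in place of 2,4-difluorophenyl on a sulfonyl sulfur. Within the data shown here, no measured step accompanies this change. Compound 1 gives only a limit in this assay. The step that the limit leaves unreadable from compound 1 to compound 4 is therefore expected to be none beyond the scatter. Compound 4 is expected to give 8000 nM in this assay, within a range from 3000 nM to 25000 nM, most likely again reported as a limit.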

Compound 4, half-maximal inhibitory concentration: > 5000 nM
Compound 4: a limit, no number; the forecaster's own chance of this, stated with the estimate: 80%; the middle value does not contradict the limit.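

Among these compounds, no step from compound 1 to compound 4 can be read in this assay: both values are limits of the assay and not numbers. The compounds shown leave open at what concentration any of them would reach half-maximal inhibition.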